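Swapping Bromo for Fluoro on a Chalcone

A few compounds are considered here, and "the series" means these few. Any claim that something is new, unique, unknown or untested is made for them only; others in the source may bear on it.

Measured compounds:
- compound 1 `COc1cc(OC)c(C(=O)/C=C/c2ccc(Br)cc2)c(OC)c1`: 68%
- compound 2 `COc1cccc(/C=C/C(=O)c2c(O)cc(OC)cc2OC)c1`: 37%
- compound 3 `COc1cc(O)c(C(=O)/C=C/c2ccccc2SC)c(OC)c1`: 28%

In a functional assay on HCT-116 cells (Homo sapiens), read by fluorescence and BrdU incorporation, with a stated time of 48 h, tested at 25 uM (on this read-out higher numbers stand for a weaker effect at the one concentration tested and lower numbers for a stronger effect), compound 1 gives the highest of the three numbers, which on this read-out means the weakest effect at the single concentration tested. Compound 2 gives a number that is lower by a margin beyond the usual scatter, and compound 3 lies lower still; both therefore show a clearly stronger effect than compound 1. Among the measured compounds shown here, no pair among the three differs in only one place, so no single structural change can be tied to any of these gaps.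

Compound 4 `COc1cc(OC)c(C(=O)/C=C/c2ccc(F)cc2)c(OC)c1` differs from compound 1 in one place: fluoro in place of bromo on an aromatic carbon. The exchange keeps the size of the molecule nearly unchanged and adds no hydrogen-bond donor or acceptor, so no large shift in this assay is expected; the step from compound 1 to compound 4 is estimated to stay within, or barely beyond, the scatter, as a number 6 percentage points higher from compound 1 to compound 4 (within the scatter). Compound 4 is therefore expected to give about 74%, in a range from 55% to 95%.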

Compound 4, a percentage reported as activity, at one concentration (the size of the read-out at that concentration, not a potency): 0.7%
Estimate against measurement, compound 4: 73.3 percentage points above, and the stated range ends above it.
By their numbers in this assay, from the lowest: compound 4; then compounds 3 and 2 (each within the scatter of the next); then compound 1.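

The exchange of bromo for fluoro gives a number 67.3 percentage points lower from compound 1 to compound 4 (beyond the scatter) in this assay. Among the compounds shown here, on the shared core, compound 4 shows a much stronger effect at the one concentration tested than compound 1. The earlier compounds shown here, among which no pair differs in only one place, could not show that this position on the aromatic ring responds so sharply, and here one atom is replaced with no ring, hydrogen-bond donor, hydrogen-bond acceptor or net charge entering or leaving. Nothing available explains why this exchange has so large an effect.

The compounds shown leave open how chloro, an amine or a carboxylic acid would read at the same position. They also leave open whether bromo and fluoro would differ this much on the cores of compound 2 or compound 3.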